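Adding a second methoxy to the diacetylamino analogue

The compounds below may be only part of what the source reports. "The series", "measured", "known", "first", "only" and "open" are said of these compounds alone.

In a functional assay on SMMC-7721 cells (Homo sapiens) for cytotoxicity, read by MTT assay, with a stated time of 48 h (a higher number here means a weaker inhibitor, a lower number a stronger inhibitor), compound 1 `COc1ccc(-c2c(-c3cc(OC)c(OC)c(OC)c3)noc2N)cc1` gives 12000 nM. Compound 2 `COc1ccc(-c2c(-c3cc(OC)c(OC)c(OC)c3)noc2N)cc1OC` reaches only a limit of this assay, at > 50000 nM. The step of an at least 4.1-fold higher number from compound 1 to compound 2 (0.61 log units; beyond the scatter) follows from methoxy in place of hydrogen on an aromatic carbon, and its true size is hidden by the limit of > 50000 nM in this assay, at which 1 of the 3 values shown sits. Compound 3 `COc1ccc(-c2c(-c3cc(OC)c(OC)c(OC)c3)noc2N(C(C)=O)C(C)=O)cc1` gives 1360 nM in this assay, the step of an 8.8-fold lower number from compound 1 to compound 3 (0.95 log units; beyond the scatter) arising from diacetylamino in place of amino on an aromatic carbon. Compound 4 `COc1ccc(-c2c(-c3cc(OC)c(OC)c(OC)c3)noc2N(C(C)=O)C(C)=O)cc1OC` differs from compound 3 by methoxy in place of hydrogen on an aromatic carbon, the same change that turned compound 1 into compound 2, now made on a core that differs from that of compound 1 by diacetylamino in place of amino on an aromatic carbon. On the basis of the step of an at least 4.1-fold higher number from compound 1 to compound 2 (0.61 log units; beyond the scatter), the step for compound 4 is expected to be a 5.1-fold higher number from compound 3 to compound 4 (0.71 log units; beyond the scatter). Compound 4 is therefore estimated at 7000 nM, between 2500 nM and 30000 nM.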

Compound 4, half-maximal inhibitory concentration: > 50000 nM
Compound 4: no number, only a limit; the forecaster's own chance of this, stated with the estimate: 15%; at least 7.1-fold (0.85 log units) between middle value and limit.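

In this assay compound 4 gives only a limit, > 50000 nM. The step of an at least 36-fold higher number from compound 3 to compound 4 (1.56 log units; beyond the scatter) runs in the same direction as the one on the core of compound 1, so the change from 4-methoxyphenyl to 3,4-dimethoxyphenyl raises the number on both cores, but this does not show whether its size carries over: the same change on two cores in this assay, an at least 4.1-fold higher number (0.61 log units; beyond the scatter) from compound 1 to compound 2 and an at least 36-fold higher number (1.56 log units; beyond the scatter) from compound 3 to compound 4; the limit leaves it open whether they differ. The step between compound 2 and compound 4 cannot be read, with both compounds at a limit: the limit of > 50000 nM in this assay, at which 2 of the 4 values shown sit.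

The compounds shown leave open how a hydroxy group, a fluorine or an ethoxy group would behave at the place of the added methoxy. They also leave open what a single acetylamino group would do in place of diacetylamino.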